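Chain length and a limit on a shared quinoline-isoxazole core

The source may report more compounds than this note shows. Statements on the series, on what has been measured and on what is new or still open speak of the compounds shown alone.

Measured compounds:
compound 1 `CCCc1cc2ccccc2nc1-c1cc(-c2ccc(F)cc2)no1`, 48400 nM
compound 2 `CCCCc1cc2ccccc2nc1-c1cc(-c2ccc(F)cc2)no1`, 24200 nM
compound 3 `CCc1cc2ccccc2nc1-c1cc(-c2ccc(C)cc2)no1`, > 100000 nM

In a functional assay on MDA-MB-231 cells (Homo sapiens) for inhibition, read by MTT assay, with a stated time of 24 h (a lower number here means a stronger inhibitor, a higher number a weaker inhibitor), compound 1 gives 48400 nM and compound 2 gives 24200 nM. The step of a 2.0-fold lower number from compound 1 to compound 2 (0.30 log units; within the scatter) is methyl in place of hydrogen on a saturated chain carbon, three bonds along the chain from an aromatic carbon. For compound 3 this assay reports only a limit, > 100000 nM, at which (the limit of > 100000 nM in this assay, at which 1 of the 3 values shown sits). The difference between the cores of compound 1 and compound 3 is not broken down here. Compound 4 `CCCc1cc2ccccc2nc1-c1cc(-c2ccc(C)cc2)no1` is not yet measured; it differs from compound 3 by methyl in place of hydrogen on a saturated chain carbon, two bonds along the chain from an aromatic carbon, the same kind of change as from compound 1 to compound 2, though the place line differs: two bonds rather than three bonds along the chain from an aromatic carbon. Resting on the small step of a 2.0-fold lower number from compound 1 to compound 2 (0.30 log units; within the scatter) and the limit of compound 3, compound 4 is expected to move little, with an at least 1.1-fold lower number from compound 3 to compound 4 (0.04 log units; that floor lies within the scatter). Compound 4 is estimated at 90000 nM, between 40000 nM and 200000 nM.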

Compound 4, half-maximal inhibitory concentration: > 100000 nM
Compound 4: no number, only a limit (the forecaster's own chance of this, stated with the estimate: 55%); middle value at least 1.1-fold (0.04 log units) away from the limit.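

In this assay compound 4 gives > 100000 nM, which is a limit and not a number, as is the value of compound 3. For the compounds shown here, the step from compound 3 to compound 4 therefore cannot be read, so it does not show whether the small step of a 2.0-fold lower number from compound 1 to compound 2 (0.30 log units; within the scatter) carries over to the other core, only that neither compound of this pair gives a number: the limit of > 100000 nM in this assay, at which 2 of the 4 values shown sit. What can be read is a different change, methyl in place of fluoro on an aromatic carbon, with an at least 2.0-fold higher number from compound 1 to compound 4 (0.31 log units; beyond the scatter).

On these data alone, it remains open whether a pentyl chain in place of the propyl chain of compound 4 would give a readable number in this assay. The same holds for an amine in place of its methyl on the aromatic carbon.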